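Fluoro for Methoxy on a Pendant Aryl Ring

The source may report more compounds than this note shows. Statements on the series, on what has been measured and on what is new or still open speak of the compounds shown alone.

Compound 1 `COc1ccc(-c2cn3ccnc3c(-c3ccc4ncn(C5CCCCC5)c4c3)n2)cc1`: 80%
Compound 2 `Fc1ccc(-c2cn3ccnc3c(-c3ccc4ncn(C5CCCCC5)c4c3)n2)cc1`: 17.6%
Compound 3 `COc1ccccc1-c1cn2ccnc2c(-c2ccc3ncn(C4CCCCC4)c3c2)n1`: 15.8%

Three compounds sharing one core were tested in a functional assay on Hs-578T cells (Homo sapiens) for inhibition, read by sulforhodamine B assay, with a stated time of 48 h, tested at 10 uM; a higher number here means more inhibition at the concentration tested (going by the name of the read-out), a lower number less inhibition. Compound 1 gives 80% in this assay. The change fluoro in place of methoxy on an aromatic carbon produces the step of a number 62.4 percentage points lower from compound 1 to compound 2 (beyond the scatter), and compound 2 gives 17.6%. The cores of compound 1 and compound 3 differ as described by 2-methoxyphenyl in place of 4-methoxyphenyl on an aromatic carbon, giving a number 64.2 percentage points lower from compound 1 to compound 3 (beyond the scatter), and compound 3 gives 15.8% in this assay. Compound 2 and compound 3 lie within the scatter of each other, as shown by a number 1.8 percentage points lower from compound 2 to compound 3 (within the scatter).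

Compound 4 `Fc1ccccc1-c1cn2ccnc2c(-c2ccc3ncn(C4CCCCC4)c3c2)n1` has not yet been measured. It differs from compound 3 by fluoro in place of methoxy on an aromatic carbon. This is the same kind of change as that from compound 1 to compound 2, but not the same: in the earlier pair the place is para to a large group, while here it is ortho to a large group.

Compound 3 is already at the lower end of the three numbers, so compound 4 is expected to move only slightly, the estimated step being a number 3.8 percentage points lower from compound 3 to compound 4 (within the scatter), because the earlier step of a number 62.4 percentage points lower from compound 1 to compound 2 (beyond the scatter) started from a high number and there is little room left below compound 3. Compound 4 is estimated at 12% in this assay, with an expected range from 0% to 35%.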

Compound 4, a percentage reported as inhibition, at one concentration (the size of the read-out at that concentration, not a potency) in the Hs-578T assay: 5.26%
The estimate for compound 4 lay 6.7 percentage points above the measured number, and the stated range covers the measured number.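

In the Hs-578T assay, fluoro in place of methoxy lowers the number on both cores, but the size of the step does not carry over: the same change on two cores in the Hs-578T assay, a number 62.4 percentage points lower (beyond the scatter) from compound 1 to compound 2 and a number 10.5 percentage points lower (beyond the scatter) from compound 3 to compound 4, 51.9 percentage points apart, beyond the scatter of two such steps

The new step is a number 10.5 percentage points lower from compound 3 to compound 4 (beyond the scatter), and compound 4 also falls short of the other two compounds, with a number 12.3 percentage points lower from compound 2 to compound 4 (beyond the scatter) and a number 74.7 percentage points lower from compound 1 to compound 4 (beyond the scatter), which leaves it lowest of the four in the Hs-578T assay. The direction of the change therefore held across these two pairs, but two pairs do not show whether the smaller step reflects the different place of the group or the low number from which compound 3 started, and they say nothing about other cores in the series. In a physicochemical assay for lipophilicity, using the shake flask method, in phosphate buffer, measured as octanol-water partition, with a stated time of 85 min, at pH 7.4 (on this read-out higher numbers stand for higher lipophilicity and lower numbers for lower lipophilicity), compound 3 gives 1.72 and compound 4 gives 1.95, and these two values lie within the scatter of each other, with a number 0.23 log units higher from compound 3 to compound 4 (within the scatter).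

The compounds shown carry only methoxy or fluoro on this aromatic ring, so it remains open whether the result for the 4-methoxyphenyl group, where in the Hs-578T assay compound 1 gives 80%, is particular to methoxy or would extend to a longer chain such as ethoxy. From the compounds shown here alone, an amine or a hydroxyl group at the same place, and any group at the remaining places on that ring, also remain open.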